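Swapping the azole on a urea methylene: triazole to pyrazole

A few compounds are considered here, and "the series" means these few. Any claim that something is new, unique, unknown or untested is made for them only; others in the source may bear on it.

Measured compounds:
compound 1 `CCOC(=O)c1ccc(NC(=O)NCc2c[nH]nn2)cc1` gives 7750 nM
compound 2 `CNS(=O)(=O)c1ccc(NC(=O)NCc2ccncc2)cc1` gives 3230 nM
compound 3 `O=C(NCc1ccncc1)Nc1ccc(S(=O)(=O)c2ccc(Cl)cc2)cc1` gives 126 nM

In an assay on isolated protein for activation of Nicotinamide phosphoribosyltransferase (Homo sapiens) (on this read-out lower numbers stand for an effect already at smaller amounts and higher numbers for an effect only at larger amounts of compound), compound 1 stands at the highest of the three numbers. Its nearest neighbour is compound 2, whose value in this assay is beyond the scatter below it, and compound 3 lies much further down still. Among the measured compounds shown here, the one step measured between single-point changes, a 26-fold lower number from compound 2 to compound 3 (1.41 log units; beyond the scatter), concerns the sulfonyl end of the shared core and says nothing about the azole carried on the other side.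

Compound 4 `CCOC(=O)c1ccc(NC(=O)NCc2cn[nH]c2)cc1` differs from compound 1 only there: 1H-pyrazol-4-yl in place of 1H-1,2,3-triazol-4-yl on a saturated chain carbon bound to an amide-type nitrogen. For the measured compounds named here, no measured pair probes this exchange; both compound 2 and compound 3 keep a pyridine on that methylene and leave the ester of compound 1 untouched. With nothing that bears on the change, the expectation for compound 4 is a value close to that of compound 1, with the range widened for the lack of a precedent. For compound 4 the expected value in this assay is 7500 nM, estimated to lie between 2500 nM and 22000 nM. The step this estimate implies, a 1.0-fold lower number from compound 1 to compound 4 (0.01 log units; within the scatter), is expected to stay within the scatter.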

Compound 4, half-maximal effective concentration: 1850 nM
For compound 4 the middle estimate is 4.1-fold (0.61 log units) above the measured one; measured number below the stated range.
By their numbers in this assay, from the lowest: compound 3; then compounds 4 and 2 (each within the scatter of the next); then compound 1.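

Among the compounds shown here, the exchange gives the first reading at this position: with the rest of the core of compound 1 unchanged, 1H-pyrazol-4-yl in place of 1H-1,2,3-triazol-4-yl on a saturated chain carbon bound to an amide-type nitrogen gives a 4.2-fold lower number from compound 1 to compound 4 (0.62 log units; beyond the scatter) in this assay and so lies beyond the usual scatter. The two rings both have 5 heavy atoms and 1 hydrogen-bond donor, while the leaving ring has 3 nitrogen and 2 hydrogen-bond acceptors and the entering ring 2 nitrogen and 1 hydrogen-bond acceptor, so this position responds to an exchange that alters these counts only slightly. Nothing available here bears on what lies behind this step.

Going by these compounds, it remains open whether the same exchange would give a step of similar size on the cores of compound 2 and compound 3, which carry a pyridine at this place and a sulfonyl group at the other end. On these data alone, it is equally open how a 1H-imidazol-4-yl ring or an aminomethyl chain at this position, or a carboxylic acid in place of the ester of compound 4, would read in this assay.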